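Cyclobutyl for propyl on the amide of a benzothiazole series

The source may hold more compounds than are shown below. What is called first, only, known or untested is meant among the compounds shown, and "the series" means these compounds.

Two compounds of this series have been run in an ADME assay on H9c2 cells (Rattus norvegicus) for cytotoxicity (a lower number here means a stronger inhibitor, a higher number a weaker inhibitor), so far. Compound 1, `O=C(Nc1nc2cccc(Cl)c2s1)C1CC1`, returned only a limit of the assay, > 50000 nM. Compound 2, `CCCC(=O)Nc1nc2ccc(Cl)cc2s1`, likewise returned only a limit, > 50000 nM. Both values therefore sit at the limit of > 50000 nM in this assay, at which 2 of the 2 values shown sit, so nothing is known of their order, and compound 2 stands at the limit along with compound 1, no number in hand for either.

Compound 3, `O=C(Nc1nc2ccc(Cl)cc2s1)C1CCC1`, is the next to be measured in this assay. It differs from compound 2 by cyclobutyl in place of propyl on a carbonyl carbon. Among the measured compounds shown here, no step between two measured compounds of this set exists to size the change, so the expectation rests on the two limits alone. In this assay the step from compound 2 to compound 3 is expected to be small, within the usual scatter, and without a direction that could be read from the data, giving a step that the limit leaves unreadable from compound 2 to compound 3. Compound 3 is accordingly estimated at 60000 nM in this assay, in a range from 30000 nM to 150000 nM, most likely reported again as a limit rather than as a number.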

Compound 3, half-maximal inhibitory concentration: > 50000 nM
Compound 3 gave a limit, no number (the forecaster's own chance of this, stated with the estimate: 85%); the middle value does not contradict the limit.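

In this assay, among the compounds shown here, compound 2 and compound 3 both gave only limits, and no step between them can be read for cyclobutyl in place of propyl on a carbonyl carbon. The compounds shown leave open whether any compound of this series gives a number rather than a limit in this assay and how compound 1, compound 2 and compound 3 would rank.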